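Removing one methyl from the acid side chain

A few compounds are considered here, and "the series" means these few. Any claim that something is new, unique, unknown or untested is made for them only; others in the source may bear on it.

In a functional assay on HL-60 cells (Homo sapiens) for antiproliferative activity, with a stated time of 72 h (a lower number here means a stronger inhibitor of growth, a higher number a weaker inhibitor of growth), compound 2 (`C=C(CCC)C(=O)c1ccc(OC(C)C(=O)O)c(C)c1C`) gives 11200 nM and compound 1 (`C=C(CCCC)C(=O)c1ccc(OCC(=O)O)c(C)c1C`) gives 14400 nM as its growth-inhibition figure. These two numbers lie within the usual scatter of each other, so no order can be read between them. Compound 3 (`C=C(CCC)C(=O)c1ccc(OCC(=O)O)c(C)c1C`) is compound 2 with hydrogen in place of methyl on a saturated chain carbon bound to a carbonyl carbon and an oxygen on an aromatic ring, which turns 1-carboxyethoxy into carboxymethoxy. For the measured compounds named here, no measured pair shows this change alone. Because compound 1 gives 14400 nM while also carrying carboxymethoxy, no shift beyond the scatter is expected in this assay in either direction. The estimated 1.2-fold higher number from compound 2 to compound 3 (0.06 log units; within the scatter) is therefore expected to be small. Compound 3 is expected at 13000 nM with an estimated range from 6500 nM to 26000 nM in this test.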

Compound 3, concentration for 50% growth inhibition: 19300 nM
Compound 3: the middle estimate sits 1.5-fold (0.17 log units) below what was measured, and the stated range covers the measured number.
By their numbers in this assay, from the lowest: compounds 2, 1 and 3 (each within the scatter of the next).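

In this assay, hydrogen in place of methyl on a saturated chain carbon bound to a carbonyl carbon and an oxygen on an aromatic ring, which turns 1-carboxyethoxy into carboxymethoxy, can now be read as a single change (a 1.7-fold higher number from compound 2 to compound 3 (0.24 log units; within the scatter)), and this methyl makes no difference that stands out from the scatter. The same holds for hydrogen in place of methyl on a saturated chain carbon, three bonds along the chain from a double-bonded chain carbon (a 1.3-fold higher number from compound 1 to compound 3 (0.13 log units; within the scatter)). No other measurement shown bears on this result.

On these data alone, whether a larger group on the first of these carbons, such as ethyl or phenyl, would give a step beyond the scatter remains open. So does the outcome of placing a methyl ester where the carboxylic acid stands.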